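A Fluoro Step Carried from One Core to Another

A few compounds are considered here, and "the series" means these few. Any claim that something is new, unique, unknown or untested is made for them only; others in the source may bear on it.

Compound 1 `CN(C)CCN1CCN(CC(=O)Nc2ccc(-c3nc4ccccc4o3)cc2)CC1` and compound 2 `CN(C)CCN1CCN(CC(=O)Nc2ccc(-c3nc4cc(F)ccc4o3)cc2)CC1` differ in one place: fluoro in place of hydrogen on an aromatic carbon. In an ADME assay on NIH3T3 cells (Mus musculus) for cytotoxicity, read by MTT assay, with a stated time of 24 h (on this read-out higher numbers stand for weaker inhibition and lower numbers for stronger inhibition), compound 1 gives 35800 nM and compound 2 gives 72000 nM, a step that reads a 2.0-fold higher number from compound 1 to compound 2 (0.30 log units; within the scatter). Compound 3 `Cc1cc(-c2nc3ccccc3o2)ccc1NC(=O)CN1CCN(CCCN(C)C)CC1` is built on a different core; the difference between the core of compound 1 and the core of compound 3 is not broken down here. In this assay compound 3 gives 33500 nM, which lies within the scatter of the value of compound 1, while the value of compound 2 stands beyond the scatter from it. Compound 4 `Cc1cc(-c2nc3cc(F)ccc3o2)ccc1NC(=O)CN1CCN(CCCN(C)C)CC1` has not yet been measured. It differs from compound 3 in one place: fluoro in place of hydrogen on an aromatic carbon. The place is the same as in the change from compound 1 to compound 2, so this is the same change set onto the core of compound 3. Because the earlier step was a 2.0-fold higher number from compound 1 to compound 2 (0.30 log units; within the scatter), compound 4 is expected to show a step of a 1.9-fold higher number from compound 3 to compound 4 (0.29 log units; within the scatter), within the scatter. Compound 4 is therefore estimated at 65000 nM, between 30000 nM and 140000 nM. The measurement will tell.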

Compound 4, half-maximal inhibitory concentration: 65700 nM
Estimate against measurement, compound 4: 1.0-fold (0.00 log units) below; low and high end bracket the measured number.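

In this assay the same replacement of hydrogen by fluoro, here 1,3-benzoxazol-2-yl to 5-fluoro-1,3-benzoxazol-2-yl, reads a 2.0-fold higher number from compound 3 to compound 4 (0.29 log units; within the scatter). Set beside the earlier step, the change carried over from one core to the other, with no gap between the two steps beyond what repeated measurement allows: the same change on two cores in this assay, a 2.0-fold higher number (0.30 log units; within the scatter) from compound 1 to compound 2 and a 2.0-fold higher number (0.29 log units; within the scatter) from compound 3 to compound 4, 1.0-fold (0.01 log units) apart, within the scatter of two such steps. Each step on its own lies within the scatter, however, so this agreement does not establish that the fluoro change moves this read-out at all, and two cores say nothing about how it would behave on a third core in the series.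

The compounds shown leave open whether another group at the same place, such as chloro, methoxy or a nitrile, would also give steps of matching size on both cores. They also leave open whether the match would hold on a core that carries a longer chain or a carboxylic acid in place of the terminal amine.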